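Removing the bromo group from compound 3

The source may report more compounds than this note shows. Statements on the series, on what has been measured and on what is new or still open speak of the compounds shown alone.

- Compound 1 `CC1OC2(C=CC(=O)C=C2)N(c2nc(-c3ccc4ccccc4c3)nn2-c2ccccc2)C1=O`: 70 nM
- Compound 2 `O=C1C=CC2(C=C1)OCC(=O)N2c1nc(-c2ccc3ccccc3c2)nn1-c1ccc2ccccc2c1`: 50 nM
- Compound 3 `O=C1C=CC2(C=C1)OCC(=O)N2c1nc(-c2ccc3ccccc3c2Br)nn1-c1ccccc1`: 50 nM

In a functional assay on MDA-MB-231 cells (Homo sapiens) for antiproliferative activity, with a stated time of 5 days (on this read-out lower numbers stand for stronger inhibition and higher numbers for weaker inhibition), compound 3 reads the same as compound 2, and its gap to compound 1 stays within the scatter. Compound 4 `O=C1C=CC2(C=C1)OCC(=O)N2c1nc(-c2ccc3ccccc3c2)nn1-c1ccccc1` has hydrogen in place of bromo on an aromatic carbon, so 1-bromonaphthalen-2-yl becomes naphthalen-2-yl (hydrogen in place of bromo on an aromatic carbon). For the measured compounds named here, no measured pair isolates this change. However, compound 1 at 70 nM and compound 2 at 50 nM both carry naphthalen-2-yl without bromo, and these values lie within the scatter of compound 3. A small rise in the number, no larger than the scatter, is therefore expected: a 1.2-fold higher number from compound 3 to compound 4 (0.08 log units; within the scatter). The estimated value for compound 4 is 60 nM, with an expected range of 25 nM to 140 nM.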

Compound 4, half-maximal inhibitory concentration: 70 nM
Estimate against measurement, compound 4: 1.2-fold (0.07 log units) below; the measured number falls inside the stated range.
By their numbers in this assay, from the lowest: compounds 2, 3, 1 and 4 (each within the scatter of the next).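

In this assay, hydrogen in place of bromo on this aromatic carbon gives a 1.4-fold higher number from compound 3 to compound 4 (0.15 log units; within the scatter) here, so the two groups read alike at this position. The other single changes also stay small: phenyl in place of naphthalen-2-yl on an aromatic nitrogen gives a 1.4-fold higher number from compound 2 to compound 4 (0.15 log units; within the scatter) here, and hydrogen in place of methyl on a saturated ring carbon gives no change at the digits printed from compound 1 to compound 4 (within the scatter) here. Nothing measured offers a reason for these results. As far as these compounds go, whether an amine, a carboxylic acid or a methoxy group on this aromatic carbon would read the same stays open.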